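The source may report more compounds than this note shows. Statements on the series, on what has been measured and on what is new or still open speak of the compounds shown alone.

Measured so far in a functional assay on DLD-1 cells (Homo sapiens), read by microscopy and crystal violet staining, with a stated time of 20 h, tested at 10 ug/mL; on this read-out lower numbers stand for less inhibition and higher numbers for more inhibition at the one concentration tested (going by the name of the read-out):
- compound 1, `COc1ccccc1COc1ccccc1/C=C/C=C1\SC(=S)NC1=O`: 98%
- compound 2, `COc1cccc(COc2ccccc2/C=C/C=C2\SC(=S)NC2=O)c1`: 82%

Compound 2 stands lowest of the two numbers, the nearest being compound 1, which sits higher by a step beyond the scatter. For the measured compounds named here, the one measured step, a number 16 percentage points lower from compound 1 to compound 2 (beyond the scatter), comes from a change of the methoxy position on the aromatic ring of the benzyl group: a 3-methoxyphenyl in place of a 2-methoxyphenyl on a saturated chain carbon bound to an oxygen on an aromatic ring.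

Compound 3, `O=C1NC(=S)S/C1=C\C=C\c1ccccc1OCc1ccncc1`, differs from compound 2 as follows: pyridin-4-yl in place of 3-methoxyphenyl on a saturated chain carbon bound to an oxygen on an aromatic ring. Going by the values given here, the measured step bears only loosely on this change, since it swapped the position of a methoxy group, whereas here the whole aromatic ring at that place is exchanged for a pyridin-4-yl; no step tells whether the number in this assay comes out higher, lower or level with a nitrogen-containing ring there. Given that the one modest step went downward and that compound 2 is already the lower of the two, a further small fall or none beyond the scatter is expected in this assay; the estimated step is a number 8 percentage points lower from compound 2 to compound 3 (within the scatter). Compound 3 is therefore expected to give about 74%, within a range of 50% to 93%.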

Compound 3, a percentage reported as inhibition, at one concentration (the size of the read-out at that concentration, not a potency): 62%
For compound 3 the middle estimate is 12 percentage points above the measured one; measured number inside the range.
By their numbers in this assay, from the lowest: compound 3; then compound 2; then compound 1.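

In this assay, the place on a saturated chain carbon bound to an oxygen on an aromatic ring now responds to an exchange of the whole ring, and not only to a shift of the methoxy group: pyridin-4-yl in place of 3-methoxyphenyl gives a number 20 percentage points lower from compound 2 to compound 3 (beyond the scatter), and pyridin-4-yl in place of 2-methoxyphenyl gives a number 36 percentage points lower from compound 1 to compound 3 (beyond the scatter). The three compounds now stand apart beyond the scatter, with the pyridin-4-yl of compound 3 at the low end, although compound 3 still gives a sizeable reading of 62%. Nothing available accounts for the fall on exchanging the ring.

The exchange removes the methoxy group and brings a ring nitrogen in a single change, so the share of each in the fall cannot be separated from these compounds; an unsubstituted phenyl at this place would read between the two. Also open, from the compounds shown here alone, are how a pyridin-3-yl or a pyridin-2-yl would compare with the pyridin-4-yl, and how the order of the three compounds would hold at other concentrations, as the read-out here is a single-concentration figure and not a potency.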